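A few compounds are considered here, and "the series" means these few. Any claim that something is new, unique, unknown or untested is made for them only; others in the source may bear on it.

In a functional assay on A549 cells (Homo sapiens) for cytotoxicity, read by MTT assay, with a stated time of 48 h (on this read-out lower numbers stand for stronger inhibition and higher numbers for weaker inhibition), compound 1 `COc1cc([C@H]2C[C@@]2(CO)C(=O)Nc2ccccc2)cc(OC)c1OC` gives > 100000 nM, which is a limit. Compound 2 `COc1cc([C@H]2C[C@]2(CO)C(=O)Nc2ccccc2)cc(OC)c1OC` gives > 100000 nM, also a limit, so it has no number of its own. Compound 3 `COc1cc([C@@H]2C[C@]2(CO)C(=O)Nc2ccccc2)cc(OC)c1OC` follows from compound 2 by one change: the two compounds have the same atoms and bonds and differ only in configuration as drawn: 1 of 2 stereo elements differ; a stereocentre at a saturated ring carbon is drawn R in compound 2 and S in compound 3. Among the compounds with values here, the only measured step of this kind is a step that the two limits leave unreadable from compound 1 to compound 2, and the fact that compounds 1 and 2 differ only in the configuration as drawn makes it the closest precedent, while the limit of > 100000 nM in this assay, at which 2 of the 2 values shown sit, leaves its size unknown. It therefore supports no direction, and no shift beyond the scatter is expected. The estimated step is a number no higher from compound 2 to compound 3 (the limit leaves the size open). For compound 3 the expected value is 100000 nM, with an estimated range of 40000 nM to 200000 nM.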

Compound 3, half-maximal inhibitory concentration: 24100 nM
Compound 3: the middle estimate sits 4.1-fold (0.62 log units) above what was measured; the measured number lies below the stated range.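

In this assay, within the data shown here, this ring stereocentre gives a readable result for the first time: an at least 4.1-fold lower number from compound 2 to compound 3 (0.61 log units; beyond the scatter). Inverting both stereocentres gives an at least 4.1-fold lower number from compound 1 to compound 3 (0.61 log units; beyond the scatter), so configuration as drawn is enough to separate compound 3 from the limits of the other two compounds: the fact that compounds 1 and 3 differ only in the configuration as drawn. The step between compound 1 and compound 2 cannot be read.

On these data alone, it remains open whether the measurable value of compound 3 holds when an amine or a carboxylic acid replaces the hydroxymethyl group. The effect of a longer chain there is equally unknown.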